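Swapping Chloro for Methoxy on a Kinase Binder

The compounds below may be only part of what the source reports. "The series", "measured", "known", "first", "only" and "open" are said of these compounds alone.

Compound 1, `COC(=O)Nc1cc(-c2cnc(OC[C@@](C)(N)CC(C)C)c(Cl)c2)ccn1`, gives 0.11 nM in an assay on brain (strain C57BL6) for displacement of a labelled ligand from AP2-associated protein kinase 1 (Mus musculus), read by scintillation counting, with a stated time of 1 h; on this read-out lower numbers stand for stronger inhibition and higher numbers for weaker inhibition.
Compound 2, `COC(=O)Nc1cc(-c2ccc(OC[C@@](C)(N)CC(C)C)c(Cl)n2)ccn1`, gives 0.17 nM in this assay.
Compound 3, `COC(=O)Nc1cc(-c2ccc(OC[C@@](C)(N)CC(C)C)c(C)c2C)ccn1`, gives 0.26 nM in this assay.

All three compounds share a common core and a (2-amino-2,4-dimethylpentyl)oxy group; they differ in the ring that carries this group and in the small substituents around it. Of the three numbers, compound 1 has the lowest. Its gap to compound 2 lies within the scatter of repeated measurements, so the two cannot be told apart, while its gap to compound 3 lies beyond the scatter.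

Compound 4, `COC(=O)Nc1cc(-c2cnc(OC[C@@](C)(N)CC(C)C)c(OC)c2)ccn1`, has not been measured in this assay. It differs from compound 1 in one place: methoxy in place of chloro on an aromatic carbon. Among the measured compounds shown here, no measured pair shows the effect of this particular swap, so the direction of the step can only be estimated. Because compound 1 already gives 0.11 nM, there is little room for a lower number, and a modest rise seems the more likely outcome, though a step no larger than the scatter is also plausible.

The expected step is a 2.0-fold higher number from compound 1 to compound 4 (0.30 log units; within the scatter). Compound 4 is estimated to give 0.22 nM in this assay, within a range from 0.07 nM to 0.7 nM.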

Compound 4, inhibition constant: 2.5 nM
Estimate against measurement, compound 4: 11-fold (1.06 log units) below; the measured number lies above the stated range.
By their numbers in this assay, from the lowest: compounds 1, 2 and 3 (each within the scatter of the next, the first and the last beyond it); then compound 4.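

In this assay, the exchange of chloro for methoxy on the aromatic carbon ortho to the (2-amino-2,4-dimethylpentyl)oxy group brings a 23-fold higher number from compound 1 to compound 4 (1.36 log units; beyond the scatter), a large step well beyond the scatter. The earlier compounds shown here differ from one another in more than one place, so they could not isolate this position; this pair shows that the choice of group on this single carbon can strongly change the number, even with the rest of the molecule held the same. The swap adds a hydrogen-bond acceptor and replaces a chlorine atom with a carbon and an oxygen, but no measurement here ties the step to either feature or explains its size.

The two compounds alone cannot show whether the rise follows the oxygen atom or the larger group as a whole. Fluoro, a nitrile or ethoxy on this same carbon of the core of compound 1 would help separate these possibilities, and a hydroxyl would show whether the methyl of the methoxy group matters.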